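Swapping a hydroxy for an isopropyl on a purine amide

A few compounds are considered here, and "the series" means these few. Any claim that something is new, unique, unknown or untested is made for them only; others in the source may bear on it.

Of the compounds shown here, three have been measured in a functional assay on the whole organism (Tail, strain ICR) with Mus musculus as the target, in the tail flick test, with a stated time of 150 min, at a dose of 25 umol/kg by the oral route; a higher number here means a stronger effect of the compound at the dose given, a lower number a weaker effect. Compound 1, `O=C(CN(c1ncnc2c1ncn2C1CCCCO1)C1CC1)N[C@@H](CO)C(=O)OCc1ccccc1`, gives 18.3% in this assay. Compound 3, `O=C(CN(c1nc(Cl)nc2[nH]cnc12)C1CC1)N[C@@H](CO)C(=O)O`, gives 18.8%, a number within the scatter of compound 1, so the two cannot be ranked. Compound 2, `CC[C@H](C)[C@H](NC(=O)CN(c1nc(Cl)nc2[nH]cnc12)C1CC1)C(=O)OCc1ccccc1`, gives 6.9%, which lies beyond the scatter below compound 1. Compound 1 therefore stands second highest of the three numbers, close to compound 3 and clearly above compound 2.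

The next compound, compound 4, is `CC(C)C[C@H](NC(=O)CN(c1ncnc2c1ncn2C1CCCCO1)C1CC1)C(=O)OCc1ccccc1`. It differs from compound 1 in one place: isopropyl in place of hydroxy on a saturated chain carbon, two bonds along the chain from an amide-type nitrogen and a carbonyl carbon. Among the compounds with values here, no measured pair shows this exact change, so the size of its effect is not known. Within the data shown here, compound 2, the one compound carrying a branched alkyl at that chain carbon, gives the lowest number of the three, while compounds 1 and 3, both with hydroxy there, sit higher. On that basis a downward step beyond the scatter is expected for a number 8.3 percentage points lower from compound 1 to compound 4 (within the scatter). Compound 4 is estimated at 10%, with a likely range from 0% to 22%.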

Compound 4, a percentage reported as activity, at one dose (the size of the read-out at that dose, not a potency): 6.47%
Compound 4: middle estimate off by 3.5 percentage points, on the high side; measured number inside the range.
By their numbers in this assay, from the lowest: compounds 4 and 2 (each within the scatter of the next); then compounds 1 and 3 (each within the scatter of the next).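

In this assay, within the data shown here, this pair gives the first direct reading of the position: isopropyl in place of hydroxy brings a number 11.8 percentage points lower from compound 1 to compound 4 (beyond the scatter). The earlier compounds shown here differed from one another in more than one place, so they could not isolate this change, whereas here the rest of the molecule stays the same. The change removes a hydrogen-bond donor and a hydrogen-bond acceptor and adds carbon, but no measurement shows which of these differences accounts for the lower number.

Because this is a single pair, it leaves open whether the same swap would give a similar step on another core. It also leaves open how an amine or a methoxy group at this chain carbon would compare with hydroxy and isopropyl.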